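A few compounds are considered here, and "the series" means these few. Any claim that something is new, unique, unknown or untested is made for them only; others in the source may bear on it.

Measured compounds in an ADME assay on MT4 cells (Homo sapiens) for cytotoxicity, read by MTT assay, with a stated time of 5 days; on this read-out higher numbers stand for lower toxicity in this test and lower numbers for higher toxicity in this test:
- compound 1 `Cc1cc(C)c(Oc2cc(Nc3ccc(C#N)cc3)[nH]c(=O)c2)c(C)c1` gives 32000 nM
- compound 2 `COc1cc(Oc2c(C)cccc2C)cc(Nc2ccc(C#N)cc2)n1` gives 8500 nM
- compound 3 `COc1cc(Oc2c(C)cc(C#N)cc2C)cc(Nc2ccc(C#N)cc2)n1` reaches only a limit of the assay, > 147000 nM

Compound 2 holds the lowest of the two numbers; compound 1 is its nearest neighbour. Among the measured compounds shown here, the one measured step, cyano in place of hydrogen on an aromatic carbon, is an at least 17-fold higher number from compound 2 to compound 3 (1.23 log units; beyond the scatter) and runs into (the limit of > 147000 nM in this assay, at which 1 of the 3 values shown sits).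

Compound 4 `COc1cc(Oc2cc(C)cc(C)c2)cc(Nc2ccc(C#N)cc2)n1` differs from compound 2 by 3,5-dimethylphenyl in place of 2,6-dimethylphenyl on an oxygen on an aromatic ring. For the measured compounds named here, no measured step moves the methyl groups on that ring, so the cyano step gives no guide here. With nothing to point either way, compound 4 is expected to stay near compound 2, a step of a 1.2-fold higher number from compound 2 to compound 4 (0.07 log units; within the scatter) within the scatter, giving an estimate of 10000 nM with a range of 3000 nM to 35000 nM.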

Compound 4, half-maximal cytotoxic concentration: 20000 nM
For compound 4 the middle estimate is 2.0-fold (0.30 log units) below the measured one; the measured number falls inside the stated range.
By their numbers in this assay, from the lowest: compound 2; then compounds 4 and 1 (each within the scatter of the next). At a limit, above all of these: compound 3.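

In this assay, the aryl group on the oxygen responds to the placing of its methyl groups alone: a 2.4-fold higher number from compound 2 to compound 4 (0.37 log units; beyond the scatter). The earlier compounds shown here showed only a cyano group added to this ring, whereas here the atoms stay the same and only their arrangement differs. No measured property at hand bears on this shift.

From the compounds shown here alone, what an amine or a carboxylic acid on this ring would give stays open. So does whether the same move of the methyl groups would carry over to the core of compound 1.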